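A Chloro-to-Bromo Exchange on the Shared Core

The source may hold more compounds than are shown below. What is called first, only, known or untested is meant among the compounds shown, and "the series" means these compounds.

Among the compounds with values here, in a functional assay on HeLa cells (Homo sapiens) for inhibition, read by MTT assay, with a stated time of 48 h (a lower number here means a stronger inhibitor, a higher number a weaker inhibitor), compound 3 `Clc1ccc(C(c2c[nH]c3ccc(Br)cc23)c2c[nH]c3ccc(Br)cc23)cc1` gives 4800 nM, the lowest of the three numbers measured so far. Compound 2 `CN(C)c1ccc(C(c2c[nH]c3ccc(Br)cc23)c2c[nH]c3ccc(Br)cc23)cc1` gives 12800 nM, and compound 1 `COc1cccc(C(c2c[nH]c3ccc(Br)cc23)c2c[nH]c3ccc(Br)cc23)c1OC` gives 64500 nM. Compound 4 `Brc1ccc(C(c2c[nH]c3ccc(Br)cc23)c2c[nH]c3ccc(Br)cc23)cc1` has not yet been measured. It differs from compound 3 in one place, with bromo in place of chloro on an aromatic carbon, para to a large group (bromo in place of chloro on an aromatic carbon).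

The nearest evidence is the modest step of a 2.7-fold lower number from compound 2 to compound 3 (0.43 log units; beyond the scatter), which also changes the group on an aromatic carbon. The large step of a 13-fold lower number from compound 1 to compound 3 (1.13 log units; beyond the scatter) and the modest step of a 5.0-fold lower number from compound 1 to compound 2 (0.70 log units; beyond the scatter) exchange the whole substituted phenyl group. None of these steps exchanges one halogen for another, so the data give no direct measure of this change. A step beyond the scatter is therefore not expected in this assay, and the expected change a 1.0-fold higher number from compound 3 to compound 4 (0.02 log units; within the scatter) is small in either direction. For compound 4 the estimated value is 5000 nM, with an expected range from 2200 nM to 11500 nM.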

Compound 4, half-maximal inhibitory concentration: 1500 nM
Compound 4: the middle estimate sits 3.3-fold (0.52 log units) above what was measured, and the stated range ends above it.
By their numbers in this assay, from the lowest: compound 4; then compound 3; then compound 2; then compound 1.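

In this assay, exchanging one halogen for another on this aromatic carbon, para to a large group, is not a neutral change: bromo in place of chloro gives a 3.2-fold lower number from compound 3 to compound 4 (0.51 log units; beyond the scatter), a step as clear as the earlier exchange of dimethylamino for chloro at the same place. With bromo there, the gap to the dimethylamino analogue widens to an 8.5-fold lower number from compound 2 to compound 4 (0.93 log units; beyond the scatter) and the exchange of the whole substituted phenyl group reaches a 43-fold lower number from compound 1 to compound 4 (1.63 log units; beyond the scatter), so compound 4 now stands lowest of the four, with each of its steps beyond the scatter. No measurement shown here accounts for the difference between the two halogens.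

The compounds shown leave open how fluoro or iodo would read on this same aromatic carbon. They also leave open how a nitrile or a trifluoromethyl group would read there.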